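Notes on the ethylsulfanyl to methylsulfanyl step

The source may hold more compounds than are shown below. What is called first, only, known or untested is meant among the compounds shown, and "the series" means these compounds.

Three measured compounds share one core and differ only in the group on an aromatic carbon: nitro, chloro or fluoro. Compound 1 `CCSc1nc2cc(S(=O)(=O)NCc3ccc([N+](=O)[O-])cc3)ccc2n1Cc1ccccc1` gives 1200 nM in an assay on isolated protein for inhibition of Gonadotropin-releasing hormone receptor (Rattus norvegicus); a higher number here means a weaker inhibitor, a lower number a stronger inhibitor. Compound 2 `CCSc1nc2cc(S(=O)(=O)NCc3ccc(Cl)cc3)ccc2n1Cc1ccccc1` gives 330 nM in this assay, and compound 3 `CCSc1nc2cc(S(=O)(=O)NCc3ccc(F)cc3)ccc2n1Cc1ccccc1` gives 200 nM in this assay. The steps of a 3.6-fold lower number from compound 1 to compound 2 (0.56 log units; beyond the scatter) and a 6.0-fold lower number from compound 1 to compound 3 (0.78 log units; beyond the scatter) lie beyond the scatter, whereas a 1.7-fold lower number from compound 2 to compound 3 (0.22 log units; within the scatter) lies within it. Compound 3 thus holds the lowest of the three numbers, but its gap to compound 2 is within the scatter, so no order between these two can be claimed.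

Compound 4 `CSc1nc2cc(S(=O)(=O)NCc3ccc(F)cc3)ccc2n1Cc1ccccc1` differs from compound 3 by hydrogen in place of methyl on a saturated chain carbon bound to a sulfur, that is ethylsulfanyl to methylsulfanyl. Going by the values given here, none of the measured steps touches this part of the molecule; all three concern the group on the aromatic carbon. Among the compounds with values here, no step therefore tells the size of the change in this assay, and the expectation is a step of no size beyond the scatter, in no preferred direction. For compound 4 the estimated step is a 1.1-fold higher number from compound 3 to compound 4 (0.04 log units; within the scatter). Compound 4 is expected to give about 220 nM in this assay, with a range from 80 nM to 600 nM that is wide for want of a comparable measured step.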

Compound 4, half-maximal inhibitory concentration: 210 nM
Estimate against measurement, compound 4: 1.0-fold (0.02 log units) above; measured number inside the range.
By their numbers in this assay, from the lowest: compounds 3, 4 and 2 (each within the scatter of the next); then compound 1.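

Hydrogen in place of methyl on a saturated chain carbon bound to a sulfur gives a 1.1-fold higher number from compound 3 to compound 4 (0.02 log units; within the scatter) in this assay, the first measured step at this part of the molecule, as all earlier steps concerned the group on the aromatic carbon. With fluoro on the aromatic carbon, the ethylsulfanyl and methylsulfanyl forms therefore cannot be told apart in this assay, and the terminal methyl of the ethyl group can go without a change beyond the scatter. No supporting measurement is available to explain this result, so the step stands as an observation only.

On these data alone, this step is read only with fluoro on the aromatic carbon, so whether ethylsulfanyl and methylsulfanyl also match with chloro or nitro there remains open. Also open, as far as these compounds go, is how far this tolerance extends, for instance to a longer chain such as butylsulfanyl, to a branched isopropylsulfanyl, or to an amine or a hydroxyl in place of the sulfur-linked chain, all of which would test this part of the molecule well beyond a single methyl.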